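The compounds below may be only part of what the source reports. "The series", "measured", "known", "first", "only" and "open" are said of these compounds alone.

Measured so far:
compound 1, `C=CC1=C(C(=O)NCCC)C(c2ccc(F)cc2)OC1`, in a functional assay on QGY7701 cells (Homo sapiens) for cytotoxicity, read by MTT assay, with a stated time of 24 h; on this read-out lower numbers stand for stronger inhibition and higher numbers for weaker inhibition: > 100000 nM
compound 2, `C=CC1=C(C(=O)Nc2ccccc2)C(c2ccc(Cl)c(Cl)c2)OC1`, in this assay: > 100000 nM

In this assay compound 1 gives > 100000 nM, which is a limit of the assay and not a number. Compound 2 likewise sits at a limit, > 100000 nM. For the measured compounds named here, the only evidence gathered so far is the limit of > 100000 nM in this assay, at which 2 of the 2 values shown sit; compound 1 therefore cannot be placed against compound 2, and nothing is known about where within the unmeasured region either stands.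

Compound 3, `C=CC1=C(C(=O)Nc2ccc(C)cc2)C(c2ccc(F)cc2)OC1`, is not yet measured. It differs from compound 1 in one place: 4-methylphenyl in place of propyl on an amide-type nitrogen. Going by the values given here, no measured step bears on this change, and compound 2, the other member of the series, also reached no measurable value. The step from compound 1 to compound 3 is expected to be a number no higher from compound 1 to compound 3 (the limit leaves the size open), that is, none beyond the scatter, with a further limit the most likely outcome. Compound 3 is accordingly estimated at 100000 nM, within a range of 30000 nM to 300000 nM.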

Compound 3, half-maximal inhibitory concentration: 59200 nM
Compound 3: middle estimate off by 1.7-fold (0.23 log units), on the high side; measured number inside the range.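

In this assay, for the compounds shown here, compound 3 is the first member of the series to give a number and not a limit, which marks the amide-type nitrogen as a place where a change can bring a value into the measurable range. Setting 4-methylphenyl in place of propyl there gives an at least 1.6-fold lower number from compound 1 to compound 3 (0.22 log units; that floor lies within the scatter). As far as these compounds go, the true size of this step stays open, since only its floor can be read, and the series is still held largely by one limit: the limit of > 100000 nM in this assay, at which 2 of the 3 values shown sit.

Open, from the compounds shown here alone, is whether the step depends on the methyl group of 4-methylphenyl or on the aromatic ring itself; compound 2 differs from compound 3 in more than one place and cannot settle this. Also open, going by these compounds, is how a benzyl group, a longer chain or a 4-methoxyphenyl group on the same nitrogen would read in this assay.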